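Swapping the aniline ring: from trifluoromethyl to trimethoxy

The source may report more compounds than this note shows. Statements on the series, on what has been measured and on what is new or still open speak of the compounds shown alone.

Of the compounds shown here, three sharing one core have been measured in a functional assay on A549 cells (Homo sapiens) for antiproliferative activity, read by MTT assay, with a stated time of 48 h; a lower number here means a stronger inhibitor, a higher number a weaker inhibitor. Compound 1 `COc1cc(N/C=C\C(=O)c2cn(-c3ccccc3)nc2-c2ccc(F)cc2)cc(OC)c1OC` gives 9350 nM in this assay. Compound 2 `COc1cc(N/C=C\C(=O)c2cn(-c3ccccc3)nc2-c2ccc(Cl)cc2)cc(OC)c1OC` gives 5640 nM. The step of a 1.7-fold lower number from compound 1 to compound 2 (0.22 log units; within the scatter) shows that this swap on the aromatic carbon changed little. Going by the values given here, compound 3 `COc1ccc(-c2nn(-c3ccccc3)cc2C(=O)/C=C\Nc2ccc(C(F)(F)F)cc2)cc1` differs from these two in two places at once, so no single step links it to them, and in this assay compound 3 gives only a limit, > 50000 nM. That limit is where one of the three values sits (the limit of > 50000 nM in this assay, at which 1 of the 3 values shown sits).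

Compound 4 `COc1ccc(-c2nn(-c3ccccc3)cc2C(=O)/C=C\Nc2cc(OC)c(OC)c(OC)c2)cc1` is not yet measured. It is made from compound 3 by the change (3,4,5-trimethoxyphenyl in place of 4-(trifluoromethyl)phenyl on an amine nitrogen). Among the compounds with values here, no measured step covers this exact change. What the numbers show is that compound 1 and compound 2, both carrying the 3,4,5-trimethoxyphenyl on the amine nitrogen, return measurable values, while compound 3, carrying the 4-(trifluoromethyl)phenyl there, returns only a limit. Compound 4 is therefore expected to move off the limit into the measurable range, with a step of about an at least 5.5-fold lower number from compound 3 to compound 4 (0.74 log units; beyond the scatter) in this assay. For compound 4 the estimate in this assay is 9000 nM, within a range from 2500 nM to 40000 nM.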

Compound 4, half-maximal inhibitory concentration: 11200 nM
Beside the measured number, compound 4's estimate is 1.2-fold (0.09 log units) below it; low and high end bracket the measured number.
By their numbers in this assay, from the lowest: compounds 2, 1 and 4 (each within the scatter of the next). At a limit, above all of these: compound 3.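

Going by these compounds alone, compound 3 and compound 4 are the first pair to isolate the group on the amine nitrogen: in this assay, 3,4,5-trimethoxyphenyl in place of 4-(trifluoromethyl)phenyl gives an at least 4.4-fold lower number from compound 3 to compound 4 (0.64 log units; beyond the scatter). Compound 3 stands at a limit of the assay rather than at a true number, so this step gives only a minimum size: the limit of > 50000 nM in this assay, at which 1 of the 4 values shown sits. With 3,4,5-trimethoxyphenyl held on the amine nitrogen, the other aromatic substituent can now be compared across three groups: methoxy in place of chloro gives a 2.0-fold higher number from compound 2 to compound 4 (0.30 log units; within the scatter), and methoxy in place of fluoro gives a 1.2-fold higher number from compound 1 to compound 4 (0.08 log units; within the scatter), so neither swap separates these compounds in this assay.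

As far as these compounds go, the change on the amine nitrogen is read here on a single pair, with methoxy on the other aromatic ring, so it remains open whether it would act the same way with fluoro or chloro there. Within the data shown here, it also remains open what a plain phenyl, or a phenyl carrying only one methoxy group or an amine, would give on the amine nitrogen, and so whether all three methoxy groups are needed for a measurable value.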